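This account rests on a few compounds, and the source may have more. Where it says the series, first, only, none or still open, it means among the compounds named here.

Three compounds share one core and were tested in a functional assay on MES-SA/Dx5 cells (Homo sapiens) for inhibition, with a stated time of 72 h; a lower number here means a stronger inhibitor, a higher number a weaker inhibitor. Compound 1 `CCOCc1cc(CN2CCCCC2)c(O)c2ncccc12` gives 776 nM, compound 2 `CCCOCc1cc(CN2CCCCC2)c(O)c2ncccc12` gives 339 nM, and compound 3 `COCc1cc(CN2CCC(C)CC2)c(O)c2ncccc12` gives 575 nM. The change from compound 1 to compound 2 is methyl in place of hydrogen on a saturated chain carbon, two bonds along the chain from an oxygen on a saturated carbon, and it made a 2.3-fold lower number from compound 1 to compound 2 (0.36 log units; beyond the scatter). How the core of compound 3 differs from that of compound 1 is not broken down here. Compound 4 `CCOCc1cc(CN2CCC(C)CC2)c(O)c2ncccc12`, not yet measured, differs from compound 3 by methyl in place of hydrogen on a saturated chain carbon bound to an oxygen on a saturated carbon, the same kind of change, though here the carbon is bound to the oxygen rather than two bonds along the chain from it. Resting on the step of a 2.3-fold lower number from compound 1 to compound 2 (0.36 log units; beyond the scatter), an estimated step of a 1.9-fold lower number from compound 3 to compound 4 (0.28 log units; within the scatter) is expected, so compound 4 is estimated to give 300 nM in this assay, between 130 nM and 700 nM.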

Compound 4, half-maximal inhibitory concentration: 468 nM
The estimate for compound 4 lay 1.6-fold (0.19 log units) below the measured number; measured number inside the range.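

In this assay, the change from methoxymethyl to ethoxymethyl gave a 1.2-fold lower number from compound 3 to compound 4 (0.09 log units; within the scatter), and methyl in place of hydrogen on a saturated ring carbon gave a 1.7-fold lower number from compound 1 to compound 4 (0.22 log units; within the scatter). Set beside the earlier chain step, the new one gives no sign that the effect of this change differs between the two cores: the same change on two cores in this assay, a 2.3-fold lower number (0.36 log units; beyond the scatter) from compound 1 to compound 2 and a 1.2-fold lower number (0.09 log units; within the scatter) from compound 3 to compound 4, 1.9-fold (0.27 log units) apart, within the scatter of two such steps. Among these compounds, this does not show that the step has a fixed size on every core, as it rests on only two pairs, and only the earlier step lies beyond the scatter.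

The compounds shown leave open whether a longer chain on the ether oxygen would continue the trend. They also leave open how an amine or a carboxylic acid at the end of that chain would read in this assay.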